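Ester and carbonate variants on a shared core

This account rests on a few compounds, and the source may have more. Where it says the series, first, only, none or still open, it means among the compounds named here.

Four compounds share one core and differ only in the group on the oxygen of the saturated ring. Compound 1 `CCCSc1nc(N[C@@H]2C[C@H]2c2ccc(F)c(F)c2)c2nnn([C@@H]3C[C@H](OC(C)=O)[C@@H](O)[C@H]3O)c2n1` carries an acetyl there; in a functional assay on the whole organism (strain Sprague-Dawley) for inhibition, with Rattus norvegicus as the target, with a stated time of 0.5 h, at a dose of 5 mg/kg by the oral route (a higher number here means more inhibition at the dose given (going by the name of the read-out), a lower number less inhibition), compound 1 gives "not determined" (no result reported). Compound 2 `CCCSc1nc(N[C@@H]2C[C@H]2c2ccc(F)c(F)c2)c2nnn([C@@H]3C[C@H](OCCOC(=O)OCC)[C@@H](O)[C@H]3O)c2n1` carries a carbonate-linked chain, and in this assay compound 2 gives 47.7%. Compound 3 `CCCSc1nc(N[C@@H]2C[C@H]2c2ccc(F)c(F)c2)c2nnn([C@@H]3C[C@H](OC(=O)C(C)(C)C)[C@@H](O)[C@H]3O)c2n1` carries a pivalate-type group, and in this assay compound 3 gives "not active" (no number reported). Within the data shown here, compound 3 thus stands with no single number, alongside compound 1 as a further entry without one, so compound 2 supplies the only number in the set. Compound 4 `CCCSc1nc(N[C@@H]2C[C@H]2c2ccc(F)c(F)c2)c2nnn([C@@H]3C[C@H](OCCOC(=O)CCC)[C@@H](O)[C@H]3O)c2n1` is not yet measured. From compound 3 to compound 4 the change is 2-((propylcarbonyl)oxy)ethyl in place of (tert-butyl)carbonyl on an oxygen on a saturated carbon. Among the measured compounds shown here, no step between measured compounds is recorded, so the expected size of the step in this assay rests on compound 2 alone: compound 4 is expected to rise above the no-activity report of compound 3 by more than the scatter, toward the level compound 2 shows at 47.7%. Compound 4 is estimated at 40%, with a range from 15% to 65%.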

Compound 4, a percentage reported as inhibition, in the whole organism at one dose (the size of the read-out at that dose, not a potency): "not active" (no number reported)
For compound 4 the study gives words and no number; there is nothing to compare the estimate with.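

In this assay compound 3 gives "not active" (no number reported) and compound 4 gives "not active" (no number reported), so no step can be read between them. No data shown bear on this result. The compounds shown leave open how the group on the oxygen relates to inhibition, since only compound 2 has a number.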